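Replacing Thiophene: What Compound 4 Should Need

A few compounds are considered here, and "the series" means these few. Any claim that something is new, unique, unknown or untested is made for them only; others in the source may bear on it.

Among three compounds sharing one core, compound 1 `O=C1NC(c2ccccc2)=C([N+](=O)[O-])C(c2cccs2)N1` gives the highest number: in an in vivo functional assay on the whole organism (heart) with Rattus norvegicus as the target (on this read-out lower numbers stand for an effect already at smaller amounts and higher numbers for an effect only at larger amounts of compound), compound 1 needs 3.5 mg/kg. Its two neighbours, compound 2 `O=C1NC(c2ccccc2)=C([N+](=O)[O-])C(c2cccnc2)N1` and compound 3 `O=C1NC(c2ccccc2)=C([N+](=O)[O-])C(c2ccccc2)N1`, differ from it only in the group on a saturated ring carbon. Compound 2 reaches 0.035 mg/kg and compound 3 reaches 0.035 mg/kg; the step of no change at the digits printed from compound 2 to compound 3 (within the scatter), so these two cannot be told apart. Against compound 1, however, both steps are large: a 100-fold lower number from compound 1 to compound 2 (2.00 log units; beyond the scatter) and a 100-fold lower number from compound 1 to compound 3 (2.00 log units; beyond the scatter). In both cases a six-membered aromatic ring stands where compound 1 carries thiophen-2-yl.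

Compound 4 `O=C1NC(c2ccccc2)=C([N+](=O)[O-])C(c2ccc(O)cc2)N1` is built the same way: 4-hydroxyphenyl in place of thiophen-2-yl on a saturated ring carbon. The entering 4-hydroxyphenyl is again a six-membered aromatic ring of carbon only, so the two measured steps from compound 1 bear directly on it. Nothing measured shows what the extra hydrogen-bond donor does on its own, so the expectation rests on the large shifts a 100-fold lower number from compound 1 to compound 2 (2.00 log units; beyond the scatter) and a 100-fold lower number from compound 1 to compound 3 (2.00 log units; beyond the scatter), widened to allow for that unknown. The expected step is a 70-fold lower number from compound 1 to compound 4 (1.85 log units; beyond the scatter). Compound 4 is therefore estimated at 0.05 mg/kg, with a range from 0.01 mg/kg to 0.35 mg/kg.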

Compound 4, minimum effective dose: 0.035 mg/kg
Estimate against measurement, compound 4: 1.4-fold (0.15 log units) above, and the stated range covers the measured number.
By their numbers in this assay, from the lowest: compounds 2, 3 and 4 (each within the scatter of the next); then compound 1.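

Going by these compounds alone, the one new change at this position is hydroxy in place of hydrogen on an aromatic carbon, and in this assay it gives no change at the digits printed from compound 3 to compound 4 (within the scatter) for a group that adds a hydrogen-bond donor to the phenyl ring. The comparison with the nitrogen-containing ring gives no change at the digits printed from compound 2 to compound 4 (within the scatter) and the comparison with the sulfur-containing ring gives a 100-fold lower number from compound 1 to compound 4 (2.00 log units; beyond the scatter) so three different six-membered aromatic groups on the saturated ring carbon now cannot be told apart, and among these four compounds only thiophen-2-yl stands apart from them. Nothing available explains the gap to thiophen-2-yl or the absence of a readable effect from the hydroxy group.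

Going by these compounds, it remains open whether an amine or a carboxylic acid in place of the hydroxy of 4-hydroxyphenyl would also leave the number where it is, or whether this tolerance belongs to hydroxy alone. On these data alone, it is equally open whether the high number of compound 1 3.5 mg/kg extends to another five-membered ring such as furan-2-yl, and how a non-aromatic cyclohexyl group or a longer chain would behave on the same saturated ring carbon.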